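From 4-fluorobenzyl to methyl on a shared core

This account rests on a few compounds, and the source may have more. Where it says the series, first, only, none or still open, it means among the compounds named here.

Of the compounds shown here, three built on a shared core have been measured so far. In a functional assay on CCRF-CEM cells (Homo sapiens) for inhibition, with a stated time of 72 h (on this read-out higher numbers stand for weaker inhibition and lower numbers for stronger inhibition), compound 3 (`COC(=O)C[C@H](NC(=O)OC(C)(C)C)C(=O)N(Cc1ccc(F)cc1)C1(C(=O)NCc2ccccc2)CCN(Cc2ccccc2)CC1`) gives 16000 nM and sits at the low end of the set, though not alone. Compound 2 (`COC(=O)C[C@H](NC(=O)OC(C)(C)C)C(=O)N(Cc1ccccc1)C1(C(=O)NC2CCCCC2)CCN(Cc2ccccc2)CC1`) gives 20000 nM in the same read-out, a number within the scatter of that of compound 3. Compound 1 (`C=CCOC(=O)N1CCC(C(=O)NCc2ccccc2)(N(Cc2ccccc2)C(=O)[C@H](CC(=O)OC)NC(=O)OC(C)(C)C)CC1`) gives 65000 nM as its number, which lies beyond the scatter from that of compound 3.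

Compound 4 (`COC(=O)C[C@H](NC(=O)OC(C)(C)C)C(=O)N(C)C1(C(=O)NCc2ccccc2)CCN(Cc2ccccc2)CC1`) has not yet been measured. Its difference from compound 3 is hydrogen in place of 4-fluorophenyl on a saturated chain carbon bound to an amide-type nitrogen and this leaves a methyl where the 4-fluorobenzyl stood, on a saturated chain carbon bound to an amide-type nitrogen. Going by the values given here, no measured pair differs in this one place, so the data hold no direct precedent for the change. The only frame is the spread of the measured numbers, with compound 3 at 16000 nM and compound 1 at 65000 nM as its two ends within the series. A moderate shift towards weaker inhibition is therefore expected in this assay for the new compound. The estimated step of a 2.5-fold higher number from compound 3 to compound 4 (0.40 log units; beyond the scatter) is a modest one in that direction. For compound 4 the estimated value is 40000 nM with an expected range from 15000 nM to 100000 nM as the likely span.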

Compound 4, half-maximal inhibitory concentration: 20000 nM
Compound 4: the middle estimate sits 2.0-fold (0.30 log units) above what was measured, and the stated range covers the measured number.
By their numbers in this assay, from the lowest: compounds 3, 2 and 4 (each within the scatter of the next); then compound 1.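

In this assay, going by these compounds alone, the swap of 4-fluorobenzyl for methyl, on a saturated chain carbon bound to an amide-type nitrogen, gives a 1.3-fold higher number from compound 3 to compound 4 (0.10 log units; within the scatter), the first direct reading of any change at this place. Within the data shown here, the 4-fluorophenyl, with its 7 heavy atoms and its six-membered aromatic ring, therefore leaves this place without a shift beyond the scatter, something the earlier compounds could not show, since each of them carries a benzyl or 4-fluorobenzyl group here and no pair among them differs at this place alone. Nothing available bears on the reason for this result.

As far as these compounds go, it remains open whether other groups at this place, such as a longer alkyl chain, an amine or a carboxylic acid, would also stay within the scatter of compound 3 and compound 4. This single pair also cannot say whether the swap would read the same way on the differently substituted cores of compound 1 and compound 2, where the benzyl group at this place stands alongside other changes.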